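Replacing phenyl with furan-2-yl on the ester

This account rests on a few compounds, and the source may have more. Where it says the series, first, only, none or still open, it means among the compounds named here.

Compound 1 `O=C(OC1CCC(CN2CCN(c3cc(=O)c4cc(C(F)(F)F)cc([N+](=O)[O-])c4s3)CC2)CC1)c1ccccc1` in an ADME assay on cells (Hepatocyte, Homo sapiens) for metabolic stability, with a stated time of 30 min; on this read-out higher numbers stand for a more stable compound and lower numbers for a less stable compound: 56.4%
Compound 2 `NC1CCC(CN2CCN(c3cc(=O)c4cc(C(F)(F)F)cc([N+](=O)[O-])c4s3)CC2)CC1`: 83.6%
Compound 3 `O=C(OC1CCC(CN2CCN(c3cc(=O)c4cc(C(F)(F)F)cc([N+](=O)[O-])c4s3)CC2)CC1)c1ccncc1`: 1%

Among these three numbers, compound 1 stands second highest, below compound 2 and above compound 3. Compound 4 `O=C(OC1CCC(CN2CCN(c3cc(=O)c4cc(C(F)(F)F)cc([N+](=O)[O-])c4s3)CC2)CC1)c1ccco1` has not yet been measured. It differs from compound 1 in one place: furan-2-yl in place of phenyl on a carbonyl carbon. In words, this is furan-2-yl in place of phenyl on a carbonyl carbon.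

Going by the values given here, two measured steps bear on this change. The closer guide is a number 55.4 percentage points lower from compound 1 to compound 3 (beyond the scatter), a large step. It also replaces the phenyl on the carbonyl carbon, in that case with pyridin-4-yl. The other is a number 27.2 percentage points higher from compound 1 to compound 2 (beyond the scatter), a modest step, but it removes the whole benzoyloxy group and so says less about a swap of one ring for another. Among the compounds with values here, no compound with a furan-2-yl group has been measured here.

Resting on compound 3 and its 1%, a lower number is expected in this assay, by a modest to large step. A single ring swap is thin evidence, so the range stays wide. For compound 4 the estimated value is 28%, with an expected range of 4% to 58%. This estimate means a number 28.4 percentage points lower from compound 1 to compound 4 (beyond the scatter).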

Compound 4, percent of the compound remaining: 1%
Compound 4: middle estimate off by 27 percentage points, on the high side; measured number outside the range, below it.
By their numbers in this assay, from the lowest: compounds 3 and 4 (each within the scatter of the next); then compound 1; then compound 2.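

In this assay the swap to furan-2-yl on the carbonyl carbon gives a number 55.4 percentage points lower from compound 1 to compound 4 (beyond the scatter) and so matches the large step already seen with pyridin-4-yl. Between the two replacement rings there is no change at the digits printed from compound 3 to compound 4 (within the scatter) even though one is the five-membered furan-2-yl, so the fall is not confined to pyridin-4-yl: among the three esters shown, only the phenyl ester of compound 1 keeps a mid-range number. Against the amino compound the new ester shows a number 82.6 percentage points lower from compound 2 to compound 4 (beyond the scatter) and thus sits as far from it as the pyridin-4-yl ester does.

Why both of these esters score so much lower than the phenyl ester cannot be told from anything available here. As far as these compounds go, it also stays open how this assay would read a thiophen-2-yl ring on the carbonyl carbon, a phenyl ring carrying a methoxy group, or an amide in place of the ester oxygen, so the boundaries of this change are still unknown.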